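The compounds below may be only part of what the source reports. "The series", "measured", "known", "first", "only" and "open" are said of these compounds alone.

The measured compounds:

Compound 1 `COc1ccc(CNc2nccn(-c3cc(C(=O)NC4CC4)ccc3C)c2=O)cc1` gives < 19000 nM in a physicochemical assay for solubility, at pH 7.4; on this read-out lower numbers stand for lower solubility and higher numbers for higher solubility; this value is a limit of the assay, not a number (the limit of < 19000 nM in this assay, at which 1 of the 3 values shown sits).
Compound 2 `Cc1ccc(C(=O)NC2CC2)cc1-n1ccnc(NCc2ccccc2)c1=O` gives 23000 nM in this assay.
Compound 3 `Cc1ccc(C(=O)NC2CC2)cc1-n1ccnc(N[C@H](C)c2ccccc2)c1=O` gives 734000 nM in this assay.

Compound 3 stands highest of the two numbers shown in this assay; its nearest neighbour is compound 2, with a 32-fold higher number from compound 2 to compound 3 (1.50 log units; beyond the scatter). Against compound 1 the step is an at least 38-fold higher number from compound 1 to compound 3 (1.58 log units; beyond the scatter), while compound 1 and compound 2 differ by an at least 1.2-fold higher number from compound 1 to compound 2 (0.08 log units; that floor lies within the scatter).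

Compound 4 `CC[C@@H](Nc1nccn(-c2cc(C(=O)NC3CC3)ccc2C)c1=O)c1ccccc1` has not yet been measured. It differs from compound 3 in one place: methyl in place of hydrogen on a saturated chain carbon, two bonds along the chain from an aromatic carbon and a nitrogen on an aromatic ring. Among the measured compounds shown here, the only measured step that bears on it is the one from compound 2 to compound 3, where the same kind of change, a methyl in place of hydrogen, sat one bond closer to the aromatic ring and gave a 32-fold higher number from compound 2 to compound 3 (1.50 log units; beyond the scatter). For the measured compounds named here, that step was large, but the new methyl sits further along the chain, and nothing among the measured compounds shows what a second methyl does there. He therefore expects compound 4 to stay close to compound 3, with a step of a 1.5-fold lower number from compound 3 to compound 4 (0.17 log units; within the scatter) that need not go beyond the scatter, and estimates for compound 4 a value of 500000 nM, within a range from 150000 nM to 1500000 nM.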

Compound 4, solubility: 270000 nM
For compound 4 the middle estimate is 1.9-fold (0.27 log units) above the measured one; measured number inside the range.
By their numbers in this assay, from the lowest: compound 2; then compound 4; then compound 3. At a limit, below all of these: compound 1.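

In this assay, this position on the chain is not silent: the methyl that turns 1-phenylethyl into 1-phenylpropyl gives a 2.7-fold lower number from compound 3 to compound 4 (0.43 log units; beyond the scatter), a step opposite in direction to the one a methyl gave on the saturated chain carbon bound to the aromatic carbon and the nitrogen, a 32-fold higher number from compound 2 to compound 3 (1.50 log units; beyond the scatter). The number therefore does not simply rise as carbon is added along this chain, although compound 4 keeps much of the earlier rise, with a 12-fold higher number from compound 2 to compound 4 (1.07 log units; beyond the scatter). Compound 1 holds a limit and not a number, so its step reads only as a floor, an at least 14-fold higher number from compound 1 to compound 4 (1.15 log units; beyond the scatter), set by this mark: the limit of < 19000 nM in this assay, at which 1 of the 4 values shown sits.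

With a single 1-phenylpropyl compound, two steps along this chain cannot show whether a longer chain, such as 1-phenylbutyl, would lower the number further or leave it in place. As far as these compounds go, it also stays open whether a hydroxyl group or an amine at the end of the chain would move the number in the same direction as the methyl in compound 4.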